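This account rests on a few compounds, and the source may have more. Where it says the series, first, only, none or still open, it means among the compounds named here.

Measured compounds:
- compound 1, `NC(=O)c1c(NC(=O)c2ccccc2Cl)sc2c1CCN(Cc1ccc(Cl)cc1Cl)C2`: 8010 nM
- compound 2, `NC(=O)c1c(NC(=O)c2ccccc2F)sc2c1CCN(Cc1ccc(Cl)cc1Cl)C2`: 13100 nM
- compound 3, `NC(=O)c1c(NC(=O)c2ccccc2Br)sc2c1CCN(C(=S)Nc1ccccc1Cl)C2`: 14600 nM

Three compounds were tested in a functional assay on HL-60 cells (Homo sapiens) for antiproliferative activity, with a stated time of 24 h; a lower number here means a stronger inhibitor, a higher number a weaker inhibitor. Compound 1 and compound 2 share a core and differ only as fluoro in place of chloro on an aromatic carbon; in this assay the step was a 1.6-fold higher number from compound 1 to compound 2 (0.21 log units; within the scatter). Compound 3 carries a different core; the difference between the two cores is not broken down here. In this assay compound 3 gives 14600 nM, and its number and those of compound 1 and compound 2 all lie within the scatter of one another.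

Compound 4, `NC(=O)c1c(NC(=O)c2ccccc2Br)sc2c1CCN(C(=S)Nc1ccccc1F)C2`, has not been measured. It stands to compound 3 as compound 2 stands to compound 1: the change is fluoro in place of chloro on an aromatic carbon, the same change that was made from compound 1 to compound 2. Because that earlier step was a 1.6-fold higher number from compound 1 to compound 2 (0.21 log units; within the scatter), the step from compound 3 to compound 4 is expected to be of similar size, namely a 1.4-fold higher number from compound 3 to compound 4 (0.16 log units; within the scatter), with the cores being different adding uncertainty. Compound 4 is therefore estimated at 21000 nM, expected between 8000 nM and 50000 nM.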

Compound 4, half-maximal inhibitory concentration: > 50000 nM
Compound 4 ended at the assay's limit; the forecaster's own chance of this, stated with the estimate: 15%; middle value at least 2.3-fold (0.37 log units) away from the limit.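

In this assay compound 4 gives > 50000 nM, which is a limit of the assay and not a number. Fluoro in place of chloro on an aromatic carbon gave an at least 3.4-fold higher number from compound 3 to compound 4 (0.53 log units; beyond the scatter), so on this core the step lies beyond the scatter, while on the other core the same change stayed within it. This does not show that the change carries over from one core to the other with the same size, nor that its size depends on the core: the same change on two cores in this assay, a 1.6-fold higher number (0.21 log units; within the scatter) from compound 1 to compound 2 and an at least 3.4-fold higher number (0.53 log units; beyond the scatter) from compound 3 to compound 4; the limit leaves it open whether they differ

The compounds shown leave open how large the step would be if compound 4 had a number instead of a limit, and the limit itself is rare among these compounds: the limit of > 50000 nM in this assay, at which 1 of the 4 values shown sits. Also open is how a methyl or a methoxy group in the same place on the phenyl ring would read in this assay, and whether fluoro in place of chloro would give a similar step on a third core.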